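The compounds below may be only part of what the source reports. "The series", "measured", "known", "first", "only" and "open" are said of these compounds alone.

Working notes on the series. In a functional assay on A549 cells (Homo sapiens) for antiproliferative activity, read by CCK-8 assay, with a stated time of 72 h (a higher number here means a weaker inhibitor, a lower number a stronger inhibitor), compound 1 `C/C(=N\O)c1ccc(OCc2ccc(C(=O)NO)cc2)cc1` gives 8930 nM and compound 2 `O=C(/C=C/c1ccc(CN2CCc3ccccc32)cc1)NO` gives 5480 nM, two values within the usual scatter of each other. Compound 3 `Nc1ccccc1NC(=O)c1ccc(COc2ccc(Cl)cc2)cc1` gives only a limit, > 32000 nM, and not a number. That reading sits at the top of the range reported here: the limit of > 32000 nM in this assay, at which 1 of the 3 values shown sits.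

Compound 4 `COc1ccc(OCc2ccc(C(=O)Nc3ccccc3N)cc2)cc1` differs from compound 3 at one place, with methoxy in place of chloro on an aromatic carbon, para to a large group (methoxy in place of chloro on an aromatic carbon). The 4-chlorophenyl thus becomes 4-methoxyphenyl. Going by the values given here, no measured pair shows this change, so the expectation rests on compound 3 and its limit of > 32000 nM. No step beyond the scatter is expected in this assay, in either direction, and another reading at the limit is the likelier outcome. The expected change is a step that the limit leaves unreadable from compound 3 to compound 4. Compound 4 is estimated at 35000 nM, with an expected range of 14000 nM to 70000 nM.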

Compound 4, half-maximal inhibitory concentration: 5530 nM
For compound 4 the middle estimate is 6.3-fold (0.80 log units) above the measured one; measured number below the stated range.
By their numbers in this assay, from the lowest: compounds 2, 4 and 1 (each within the scatter of the next). At a limit, above all of these: compound 3.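

Going by these compounds alone, the position on the six-membered aromatic ring of carbon only, para to a large group, is the first place where a single change can be read: in this assay, 4-methoxyphenyl in place of 4-chlorophenyl gives an at least 5.7-fold lower number from compound 3 to compound 4 (0.76 log units; beyond the scatter). Within the data shown here, compound 3 remains the only reading at a limit, so this step is a bound and not a measured size: the limit of > 32000 nM in this assay, at which 1 of the 4 values shown sits. The change replaces a chloro with no hydrogen-bond acceptor by a methoxy with one, but this single pair ties the step to neither that count nor any other property.

A hydroxy group, an amine or a longer chain such as ethoxy at this position would test what the step depends on. Going by these compounds, whether the step carries over to other cores also stays open.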